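From Formylphenyl to Naphthyl on a Shared Core

This account rests on a few compounds, and the source may have more. Where it says the series, first, only, none or still open, it means among the compounds named here.

Of the compounds shown here, two of one series have been measured in a functional assay on CAKI-1 cells (Homo sapiens) for inhibition, read by sulforhodamine B assay, with a stated time of 48 h, tested at 10 uM; on this read-out lower numbers stand for less inhibition and higher numbers for more inhibition at the one concentration tested (going by the name of the read-out). Compound 1 `CCc1ccc(-c2cn3ccnc3c(-c3ccc4ncn(Cc5ccccc5)c4c3)n2)cc1` gives 47.9%. Compound 2 `O=Cc1ccc(-c2cn3ccnc3c(-c3ccc4ncn(Cc5ccccc5)c4c3)n2)cc1` gives 36.6%. Within the data shown here, the single step between them, a number 11.3 percentage points lower from compound 1 to compound 2 (beyond the scatter), leaves compound 2 with the lower of the two numbers, and its nearest neighbour compound 1 stands higher by that step.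

Compound 3 `c1ccc(Cn2cnc3ccc(-c4nc(-c5cccc6ccccc56)cn5ccnc45)cc32)cc1` has not yet been measured. It differs from compound 2 in one place: naphthalen-1-yl in place of 4-formylphenyl on an aromatic carbon. Among the measured compounds shown here, no measured step exchanges one aromatic group for another of this kind, so only the step from compound 1 to compound 2 bears on the change, and it does so loosely, in that compound 1 carries no formyl group either. That step was modest. Going by these compounds, the removal of the formyl group in going to compound 3 is expected to move the number back up by a comparable modest amount, a number 8.4 percentage points higher from compound 2 to compound 3 (within the scatter), though the naphthalen-1-yl group itself is untested here and widens the uncertainty. Compound 3 is therefore estimated to give 45%, with a range from 25% to 65%.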

Compound 3, a percentage reported as inhibition, at one concentration (the size of the read-out at that concentration, not a potency): 27.1%
Estimate against measurement, compound 3: 17.9 percentage points above; measured number inside the range.
By their numbers in this assay, from the lowest: compounds 3 and 2 (each within the scatter of the next); then compound 1.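

In this assay, placing naphthalen-1-yl where 4-formylphenyl stood on this aromatic carbon gives a number 9.5 percentage points lower from compound 2 to compound 3 (within the scatter), so on this read-out the two groups cannot be told apart. Set against 4-ethylphenyl, the same group gives a number 20.8 percentage points lower from compound 1 to compound 3 (beyond the scatter), which shows that the absence of the formyl group does not by itself bring the number back to that of compound 1: compound 3 carries no formyl group either, yet it stands apart from compound 1 beyond the scatter. Nothing measured for these compounds accounts for the differences between these aromatic groups.

Going by these compounds, it remains open how the number in this assay would respond to an amine, a carboxylic acid or a longer chain in place of the ethyl group of compound 1. Since each compound is read at one concentration only, the numbers also leave open how the three compounds would compare across a range of concentrations.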